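This account rests on a few compounds, and the source may have more. Where it says the series, first, only, none or still open, it means among the compounds named here.

The measured compounds:
Compound 1 `CCCCCCCCCCCCn1nnc(C(NC(=O)c2cccc([N+](=O)[O-])c2)c2ccccc2)n1` gives 80 nM in an assay on microsomes from liver for inhibition of sterol O-acyltransferase 1 (Rattus norvegicus); a lower number here means a stronger inhibitor, a higher number a weaker inhibitor.
Compound 2 `CCCCCCCCCCCCn1nnc(C(NC(=O)c2ccccc2[N+](=O)[O-])c2ccccc2)n1` gives 240 nM in this assay.
Compound 3 `CCCCCCCCCCCCn1nnnc1C(NC(=O)c1ccc(F)cc1F)c1ccccc1` gives 380 nM in this assay.

Compound 3 stands at the highest of the three numbers; its value is within the scatter of that of compound 2, and beyond the scatter of that of compound 1. Compound 4 `CCCCCCCCCCCCn1nnnc1C(NC(=O)c1ccnc(SC)c1)c1ccccc1` differs from compound 3 in one place: a group of 8 heavy atoms (6 carbon, 1 nitrogen, 1 sulfur; one six-membered aromatic ring with 1 hetero atom) in place of a group of 8 heavy atoms (6 carbon, 2 fluorine; one six-membered aromatic ring of carbon only), on a carbonyl carbon. For the measured compounds named here, the only single-point step that has been measured is a 3.0-fold higher number from compound 1 to compound 2 (0.48 log units; beyond the scatter), which concerns a change of substituent position on the same benzoyl ring and is of modest size. Going by the values given here, no measured step touches a swap of the whole aromatic ring on the carbonyl carbon, nor the entry of a ring with one hetero atom bearing a methylthio group, so there is nothing in the data that points to a direction. The expectation is therefore a step of no more than modest size, with no reliable sign, so that compound 4 is estimated at 300 nM (range 80 nM to 1200 nM), which means an expected step of a 1.3-fold lower number from compound 3 to compound 4 (0.10 log units; within the scatter).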

Compound 4, half-maximal inhibitory concentration: 140 nM
For compound 4 the middle estimate is 2.1-fold (0.33 log units) above the measured one, and the stated range covers the measured number.
By their numbers in this assay, from the lowest: compounds 1, 4, 2 and 3 (each within the scatter of the next, the first and the last beyond it).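

On the carbonyl carbon of the amide, the 2,4-difluorophenyl group can be given up for a six-membered aromatic ring with one hetero atom and a sulfur-bearing group: the exchange gives a 2.7-fold lower number from compound 3 to compound 4 (0.43 log units; beyond the scatter) in this assay, a modest gain rather than a loss. For the compounds shown here, the earlier compounds showed only that moving a nitro group around one benzoyl ring shifts the number, whereas this step shows that the ring itself can be replaced at this place on the shared core of compound 3. Nothing available here explains the change.

Going by these compounds alone, the single step cannot separate the ring nitrogen from the methylthio group, so the share of each remains open. On these data alone, whether a methoxy group or an amine in place of the methylthio group would hold the number also remains unknown.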